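A few compounds are considered here, and "the series" means these few. Any claim that something is new, unique, unknown or untested is made for them only; others in the source may bear on it.

In a functional assay on PC-3 cells (Homo sapiens) for antiproliferative activity, read by MTT assay, with a stated time of 48 h (on this read-out higher numbers stand for weaker inhibition and lower numbers for stronger inhibition), compound 1 (`Cc1cccn2cc(-c3nnc(-c4ccccc4)o3)nc12`) gives 22800 nM, compound 2 (`Cc1cccn2cc(-c3nnc(-c4ccc(Br)cc4)o3)nc12`) gives 37800 nM and compound 3 (`COc1ccc(-c2nnc(-c3cn4cccc(C)c4n3)o2)cc1`) gives 11800 nM on the same shared core. Compound 2 sits at the upper end of these numbers, alongside compound 1 and apart from compound 3. Compound 4 (`Cc1cccn2cc(-c3nnc(-c4ccccc4I)o3)nc12`) has 2-iodophenyl in place of 4-bromophenyl on an aromatic carbon. For the measured compounds named here, no measured compound carries iodine, so the guidance here is only indirect. Putting bromo in place of hydrogen gave a 1.7-fold higher number from compound 1 to compound 2 (0.22 log units; within the scatter) and putting methoxy in place of hydrogen gave a 1.9-fold lower number from compound 1 to compound 3 (0.29 log units; within the scatter) in the measured set. The largest measured change, methoxy in place of bromo, gave only a 3.2-fold lower number from compound 2 to compound 3 (0.51 log units; beyond the scatter) and was modest. A small change is therefore expected in this assay, and the expected step, a 1.5-fold lower number from compound 2 to compound 4 (0.18 log units; within the scatter) as estimated here, stays within the scatter. For compound 4 the estimated value is 25000 nM with an expected range from 10000 nM to 60000 nM in this test.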

Compound 4, half-maximal inhibitory concentration: 33500 nM
For compound 4 the middle estimate is 1.3-fold (0.13 log units) below the measured one; measured number inside the range.
By their numbers in this assay, from the lowest: compounds 3, 1, 4 and 2 (each within the scatter of the next, the first and the last beyond it).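

In this assay, placing 2-iodophenyl on the shared core in place of 4-bromophenyl gives a 1.1-fold lower number from compound 2 to compound 4 (0.05 log units; within the scatter), while iodo in place of hydrogen gives a 1.5-fold higher number from compound 1 to compound 4 (0.17 log units; within the scatter). For the compounds shown here, this is the first look at iodine and at a group on a different ring carbon, and neither change separates compound 4 from compound 2 or compound 1 in this assay, although the swap from compound 2 changes the halogen and its place on the ring together. Nothing available explains why these numbers stay so close.

The compounds shown cannot tell what the halogen and its ring place each contribute, which 2-bromophenyl and 4-iodophenyl would help to separate. On these data alone, it also remains open whether an amine or a carboxylic acid on this ring would shift the number beyond the scatter.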